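A few compounds are considered here, and "the series" means these few. Any claim that something is new, unique, unknown or untested is made for them only; others in the source may bear on it.

Working notes on the series. Three compounds have numbers in an assay on isolated protein for inhibition of Voltage-dependent L-type calcium channel subunit alpha-1C (Cavia porcellus); on this read-out higher numbers stand for weaker inhibition and lower numbers for stronger inhibition. Compound 1 `CC1=C(C(=O)OC(C)(C)C)C(c2[nH]cnc2Cl)C(C(=O)OC(C)(C)C)=C(C)N1` gives 4070 nM and stands with the highest number of the three. Compound 2 `CC1=C(C(=O)OCC2CCCCC2)C(c2[nH]cnc2Cl)C(C(=O)OCC2CCCCC2)=C(C)N1` gives 631 nM in this assay, and its number is lower than that of compound 1 by a margin beyond the scatter. Compound 3 `CC1=C(C(=O)OCc2ccccc2)C(c2nc[nH]c2Cl)C(C(=O)OCc2ccccc2)=C(C)N1` gives 41.7 nM in this assay, the lowest number of the three, and its gap to compound 1 lies well beyond the scatter. No two of the measured compounds differ in one place only, so none of these gaps can be read as a single step.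

Compound 4 `CCOC(=O)C1=C(C)NC(C)=C(C(=O)OC(C)(C)C)C1c1[nH]cnc1Cl` is not yet measured. It differs from compound 1 in one place: ethyl in place of tert-butyl on an oxygen next to a carbonyl group. In this assay a step towards a lower number is expected from compound 1, of moderate size, as a 3.4-fold lower number from compound 1 to compound 4 (0.53 log units; beyond the scatter). Compound 4 is therefore expected to give about 1200 nM in this assay, within a range from 300 nM to 4500 nM.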

Compound 4, half-maximal inhibitory concentration: 1660 nM
For compound 4 the middle estimate is 1.4-fold (0.14 log units) below the measured one; the range from low to high includes it.
By their numbers in this assay, from the lowest: compound 3; then compound 2; then compound 4; then compound 1.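

In this assay the series now has a single change that can be read on its own: ethyl in place of tert-butyl on an oxygen next to a carbonyl group gives a 2.5-fold lower number from compound 1 to compound 4 (0.39 log units; beyond the scatter). The step is modest but beyond the scatter, so this position alone moves the number, and the lower number goes with the ethyl group, which has the fewer heavy atoms, while the other ester of compound 4 keeps its tert-butyl. No measurement at hand bears on why the step runs this way.

On these data alone, it remains open whether ethyl in place of the second tert-butyl would add a further step of similar size. As far as these compounds go, how methyl, a longer chain or a chain ending in an amine would read on this oxygen also remains open.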